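Ester group exchange from compound 2 to compound 3

A few compounds are considered here, and "the series" means these few. Any claim that something is new, unique, unknown or untested is made for them only; others in the source may bear on it.

Measured so far in a functional assay on MDA-MB-231 cells (Homo sapiens) for antiproliferative activity, read by MTT assay, with a stated time of 72 h; a higher number here means a weaker inhibitor, a lower number a stronger inhibitor
- compound 1 `CC1=CC[C@H]2[C@H](CC[C@]2(C)O)C(C)(C)[C@@H]1CC[C@H]1[C@]2(C)CC[C@H](OC(=O)c3ccccc3F)C(C)(C)O[C@H]2CC[C@@]1(C)O` gives 28700 nM
- compound 2 `CC1=CC[C@H]2[C@H](CC[C@]2(C)O)C(C)(C)[C@@H]1CC[C@H]1[C@]2(C)CC[C@H](OC(=O)c3ccc(C(F)(F)F)cc3F)C(C)(C)O[C@H]2CC[C@@]1(C)O` gives 36300 nM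

Going by the values given here, compound 2 stands level with the only other measured compound. Among the compounds with values here, the single measured step (a 1.3-fold higher number from compound 1 to compound 2 (0.10 log units; within the scatter)) puts trifluoromethyl in place of hydrogen on an aromatic carbon and stays within the scatter.

Compound 3 `CC1=CC[C@H]2[C@H](CC[C@]2(C)O)C(C)(C)[C@@H]1CC[C@H]1[C@]2(C)CC[C@H](OC(=O)c3ccc([N+](=O)[O-])o3)C(C)(C)O[C@H]2CC[C@@]1(C)O` carries 5-nitrofuran-2-yl in place of 2-fluoro-4-(trifluoromethyl)phenyl on a carbonyl carbon. Within the data shown here, the measured step bears on this only loosely, since it leaves the aromatic ring in place, and no measured compound carries 5-nitrofuran-2-yl. The data therefore give no direction, and no step beyond the scatter is expected in this assay. The range stays wide. The estimate means a 1.3-fold lower number from compound 2 to compound 3 (0.11 log units; within the scatter) (expected, not measured). The estimated value for compound 3 is 28000 nM (expected range 10000 nM to 70000 nM).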

Compound 3, half-maximal inhibitory concentration: 11100 nM
Beside the measured number, compound 3's estimate is 2.5-fold (0.40 log units) above it; the range from low to high includes it.
By their numbers in this assay, from the lowest: compound 3; then compounds 1 and 2 (each within the scatter of the next).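

In this assay, going by these compounds alone, the group on the carbonyl carbon of the ester is the first place where a change moves the number beyond the scatter: 5-nitrofuran-2-yl gives a 3.3-fold lower number from compound 2 to compound 3 (0.51 log units; beyond the scatter) against the 2-fluoro-4-(trifluoromethyl)phenyl ester and a 2.6-fold lower number from compound 1 to compound 3 (0.41 log units; beyond the scatter) against the 2-fluorophenyl ester. Both steps are modest, yet each exceeds the earlier trifluoromethyl step, which stayed within the scatter, so among these three compounds exchanging the whole aromatic group changes the number more than adding trifluoromethyl to the phenyl ring does. Nothing available accounts for this step.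

The compounds shown do not separate the contribution of the furan ring from that of the nitro group, which an unsubstituted furan-2-yl ester and a 4-nitrophenyl ester would address. From the compounds shown here alone, how an amine or a carboxylic acid on the aromatic group would read here also remains open.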